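A few compounds are considered here, and "the series" means these few. Any claim that something is new, unique, unknown or untested is made for them only; others in the source may bear on it.

Measured so far:
compound 1, `CCCCCCCCCCCCCCNCC(N)CCCCN`: 251 nM
compound 2, `CCCCCCCCCCCCCCNC(=O)[C@@H](N)CCCCN`: 501 nM
compound 3, `CCCCCCCCCCCCNC(=O)[C@H](N)CCCCN`: 794 nM

All three values come from a functional assay on HL-60 cells (Homo sapiens) for activation; a higher number here means that more compound is needed for the effect, a lower number that less compound is needed. In this assay, compound 1 gives 251 nM, which lies within the scatter of the value for compound 2 and beyond the scatter from the higher number of compound 3. Compound 2 at 501 nM and compound 3 at 794 nM lie within the scatter of each other.

The next compound in view is compound 4 (`CCCCCCCCCCCCNCC(N)CCCCN`), which has not yet been measured. It differs from compound 1 by hydrogen in place of ethyl on a saturated chain carbon, ten or more bonds along the chain from an amine nitrogen.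

Going by the values given here, no measured pair shows this change on its own, so the expectation rests on little. A modest step towards a higher number is expected in this assay, around the edge of the scatter. Among the compounds with values here, the only guide is compound 3 at 794 nM, whose gap from compound 1 is the one gap beyond the scatter so far. The estimated step is a 2.0-fold higher number from compound 1 to compound 4 (0.30 log units; within the scatter). Compound 4 is expected at about 500 nM, with an estimated range from 200 nM to 1250 nM.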

Compound 4, half-maximal effective concentration: 501 nM
Beside the measured number, compound 4's estimate is 1.0-fold (0.00 log units) below it, and the stated range covers the measured number.
By their numbers in this assay, from the lowest: compounds 1, 2, 4 and 3 (each within the scatter of the next, the first and the last beyond it).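

In this assay, going by these compounds alone, this is the first pair of compounds that differ in one place only, so a single change can now be read on its own: hydrogen in place of ethyl on a saturated chain carbon, ten or more bonds along the chain from an amine nitrogen, gives a 2.0-fold higher number from compound 1 to compound 4 (0.30 log units; within the scatter). At this position, then, losing the ethyl leaves the number within the scatter, and the pair gives no sign that the two carbons it carries matter in this assay. Nothing available gives a reason for this step.

One pair says little about the chain as a whole, and compound 2 and compound 3 differ in more than one place, so they cannot show whether the same change behaves alike when a carbonyl is present. Also open, from the compounds shown here alone, is whether a longer chain, or a phenyl group in place of ethyl at this position, would move the number beyond the scatter.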